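The compounds below may be only part of what the source reports. "The series", "measured", "known", "first", "only" and "open" are said of these compounds alone.

Three compounds of the series have numbers in a functional assay for activation of Alpha-1A adrenergic receptor (Homo sapiens), read by calcium flux; a higher number here means that more compound is needed for the effect, a lower number that less compound is needed. Compound 2 `c1csc(-c2ccccc2OCC2=NCCN2)c1` gives 1 nM, the lowest of the three numbers. Compound 3 `c1ccc(-c2ccns2)c(OCC2=NCCN2)c1` gives 5.01 nM, and compound 1 `Cc1cccc(-c2ccccc2OCC2=NCCN2)n1` gives 126 nM. For the measured compounds named here, the single step between compounds differing in one place, a 5.0-fold higher number from compound 2 to compound 3 (0.70 log units; beyond the scatter), shows that exchanging the five-membered ring itself costs a modest amount. Compound 4 `Cc1ccc(-c2ccccc2OCC2=NCCN2)s1` awaits measurement in this assay; it differs from compound 2 by methyl in place of hydrogen on an aromatic carbon. Going by the values given here, no measured step adds a methyl to a ring of this kind. Among the compounds with values here, compound 1 is the only compound carrying a methyl, but on the other aromatic ring of the shared core, and no single-place step connects it to any other compound, so its number shows only that it lies far from compound 2. The step from compound 2 to compound 3 touches the same ring but changes a ring atom, not a substituent, so it bears on compound 4 only loosely. A small methyl at this position is expected to leave the number close to that of compound 2, with a slight loss counted as the more likely direction. Compound 4 is therefore estimated at 2.5 nM, within 0.6 nM to 10 nM. That estimate means a 2.5-fold higher number from compound 2 to compound 4 (0.40 log units; beyond the scatter), a step expected to fall near the edge of the scatter.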

Compound 4, half-maximal effective concentration: 25.1 nM
Beside the measured number, compound 4's estimate is 10-fold (1.00 log units) below it; measured number outside the range, above it.
By their numbers in this assay, from the lowest: compound 2; then compound 3; then compound 4; then compound 1.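

In this assay, the carbon next to the ring sulfur proves sensitive to even a small addition: methyl in place of hydrogen gives a 25-fold higher number from compound 2 to compound 4 (1.40 log units; beyond the scatter), a large step for a single added heavy atom. The thiophen-2-yl to 5-methylthiophen-2-yl change therefore costs more than the earlier exchange of the five-membered ring, a 5.0-fold higher number from compound 2 to compound 3 (0.70 log units; beyond the scatter), and the direct comparison between the two substituted aryl groups gives a 5.0-fold higher number from compound 3 to compound 4 (0.70 log units; beyond the scatter). Nothing at hand bears on what lies behind this loss.

On these data alone, whether fluorine, a longer chain such as ethyl, or an amine on this carbon would behave like methyl remains open. Also open, as far as these compounds go, is whether methyl on another carbon of the same ring would give a step of this size.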